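The compounds below may be only part of what the source reports. "The series", "measured", "known", "first", "only" and "open" are said of these compounds alone.

Three compounds built on a shared core have so far been examined in an in vitro functional assay on HEK293-A cells for negative allosteric modulation of metabotropic glutamate receptor 5 (Homo sapiens), read by FLIPR and calcium flux; on this read-out higher numbers stand for weaker inhibition and lower numbers for stronger inhibition. Compound 1 `O=C1CC(c2nc(-c3cccc(Cl)c3)no2)CN1c1ccc(Cl)c(Cl)c1` reaches only a limit of the assay, > 10000 nM. Compound 2 `O=C1CC(c2nc(-c3cccc(Cl)c3)no2)CN1Cc1ccc(F)cc1` gives 3600 nM, and compound 3 `Cc1cccc(N2CC(c3nc(-c4cccc(Cl)c4)no3)CC2=O)c1` gives 2300 nM. Compound 3 therefore holds the lowest of the two numbers, with compound 2 nearest; the gap a 1.6-fold lower number from compound 2 to compound 3 (0.19 log units; within the scatter) lies within the scatter, so neither compound can be placed ahead of the other. The steps of an at least 2.7-fold lower number from compound 1 to compound 2 (0.44 log units; beyond the scatter) and an at least 4.3-fold lower number from compound 1 to compound 3 (0.63 log units; beyond the scatter) are each at least modest, and their size can only be bounded because compound 1 sits at the limit of > 10000 nM in this assay, at which 1 of the 3 values shown sits.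

Compound 4 `CC(C)CN1CC(c2nc(-c3cccc(Cl)c3)no2)CC1=O` exchanges the aromatic group on the ring nitrogen for a branched chain: isobutyl in place of 3-methylphenyl on an amide-type nitrogen in a ring. Among the compounds with values here, no measured step swaps an aromatic group for a chain at this position; the two that bear on it, an at least 4.3-fold lower number from compound 1 to compound 3 (0.63 log units; beyond the scatter) and a 1.6-fold lower number from compound 2 to compound 3 (0.19 log units; within the scatter), show that exchanging one group there for another moves the number by a modest amount at most beyond the scatter. On that footing compound 4 is expected to show a 2.6-fold higher number from compound 3 to compound 4 (0.42 log units; beyond the scatter), leaning toward weaker inhibition. The estimate for compound 4 is 6000 nM, with a range from 2000 nM to 20000 nM.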

Compound 4, half-maximal inhibitory concentration: 920 nM
For compound 4 the middle estimate is 6.5-fold (0.81 log units) above the measured one; measured number below the stated range.
By their numbers in this assay, from the lowest: compound 4; then compounds 3 and 2 (each within the scatter of the next). At a limit, above all of these: compound 1.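

Within the data shown here, compound 4 shows that an aromatic ring on the amide-type nitrogen is not required in this assay: the isobutyl chain, with no ring and fewer heavy atoms than 3-methylphenyl, gives a 2.5-fold lower number from compound 3 to compound 4 (0.40 log units; beyond the scatter), the first step beyond the scatter among the compounds that show a measured number. The same direction holds against the benzyl group of compound 2, with isopropyl in place of 4-fluorophenyl on the saturated chain carbon bound to that nitrogen giving a 3.9-fold lower number from compound 2 to compound 4 (0.59 log units; beyond the scatter), so among the four compounds the one with no aromatic ring at this position has the lowest number. The widest step, an at least 10-fold lower number from compound 1 to compound 4 (1.03 log units; beyond the scatter), can only be bounded because compound 1 stands at a limit, not at a number: the limit of > 10000 nM in this assay, at which 1 of the 4 values shown sits.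

From the compounds shown here alone, how a straight butyl chain, a longer chain or a cyclohexyl ring would compare at this nitrogen stays open, and with it whether the branching of isobutyl matters or only the absence of an aromatic ring. Also open, going by these compounds, is how an amine or an ether oxygen placed along such a chain would move the number.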